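The source may hold more compounds than are shown below. What is called first, only, known or untested is meant among the compounds shown, and "the series" means these compounds.

Of the compounds shown here, three sharing one core have been measured in a functional assay on PC-3 cells (Homo sapiens) for antiproliferative activity, read by MTT assay; on this read-out higher numbers stand for weaker inhibition and lower numbers for stronger inhibition. Compound 1 `CCCSc1ncnc2ccc(I)cc12` gives 40900 nM; compound 2 `CCSc1ncnc2ccc(I)cc12` gives 38900 nM; compound 3 `C=CCSc1ncnc2ccc(I)cc12` gives 28800 nM. The three differ only in the chain carried on the sulfur, and the steps among them are small: a 1.1-fold lower number from compound 1 to compound 2 (0.02 log units; within the scatter), a 1.4-fold lower number from compound 1 to compound 3 (0.15 log units; within the scatter) and a 1.4-fold lower number from compound 2 to compound 3 (0.13 log units; within the scatter). Compound 3 thus has the lowest of the three numbers, but both of its gaps to the others lie within the scatter, so the three are best read as alike.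

Compound 4 `C=CCSc1ncnc2ccccc12` keeps the chain of compound 3 and changes the ring instead: hydrogen in place of iodo on an aromatic carbon. Among the measured compounds shown here, none of the measured steps touches the iodo, so no measured step bears directly on this change; the only guidance is that all three iodo-bearing compounds sit in the same weak range. With no comparison to lean on, the expectation for this assay is open in both directions, and the estimate is centred near a modest rise in the number. Compound 4 is therefore expected to give about 45000 nM, within a wide range from 15000 nM to 140000 nM, corresponding to an expected step of a 1.6-fold higher number from compound 3 to compound 4 (0.19 log units; within the scatter).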

Compound 4, half-maximal inhibitory concentration: 48000 nM
Estimate against measurement, compound 4: 1.1-fold (0.03 log units) below; the measured number falls inside the stated range.
By their numbers in this assay, from the lowest: compounds 3, 2, 1 and 4 (each within the scatter of the next).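

Among the compounds shown here, replacing iodo with hydrogen changes a part of the molecule that stayed fixed in the earlier compounds, and it gives a 1.7-fold higher number from compound 3 to compound 4 (0.22 log units; within the scatter) in this assay and so leaves the two compounds alike. The iodine is the only heavy atom lost in this change, so on this read-out the iodo is not shown to matter for the number, at least when the chain of compound 3 sits on the sulfur. This single pair gives a result for one chain only, and nothing here can explain the absence of a clear change, as no supporting measurement bears on it.

With only iodo and hydrogen shown on this aromatic carbon, it remains open whether a different group there, such as an amine or a carboxylic acid, would shift the number beyond the usual scatter. From the compounds shown here alone, it also remains open whether removing the iodo would leave the number just as unchanged with the propyl or ethyl chains on the sulfur, and whether a much longer chain there would change the picture.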